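A few compounds are considered here, and "the series" means these few. Any claim that something is new, unique, unknown or untested is made for them only; others in the source may bear on it.

Measured compounds:
- Compound 1 `CC(C)OCC1n2cncc2CN([C@@H](C)c2ccc(Cl)cc2)S1(=O)=O` gives 0.8 nM in an assay on cells for inhibition of cytochrome P450 11B2, mitochondrial (Homo sapiens); a lower number here means a stronger inhibitor, a higher number a weaker inhibitor.
- Compound 2 `C[C@@H](c1ccc(Cl)cc1)N1Cc2cncn2C(C[C@H](O)c2ccccc2)S1(=O)=O` gives 0.3 nM in this assay.

Within the data shown here, of these two numbers, compound 2 holds the lower one, and its only neighbour is compound 1, which sits a 2.7-fold lower number from compound 1 to compound 2 (0.43 log units; beyond the scatter) apart from it. The two differ at a single spot: a saturated chain carbon bound to a saturated ring carbon of the shared core, where compound 1 carries an isopropoxy group and compound 2 carries a hydroxy(phenyl)methyl group.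

Compound 3 `COC(C)(C)CC1n2cncc2CN([C@@H](C)c2ccc(Cl)cc2)S1(=O)=O` keeps that core and changes the same spot again: 1-methoxy-1-methylethyl in place of hydroxy(phenyl)methyl on a saturated chain carbon bound to a saturated ring carbon. Among the measured compounds shown here, the one measured step that bears on this is the step from compound 1 to compound 2, in which a small ether group was exchanged for the larger hydroxylated ring-bearing group and the number fell modestly. The group entering in compound 3 resembles the isopropoxy of compound 1 more than the hydroxy(phenyl)methyl of compound 2, so the expectation is that this change is undone in part, with the number rising back toward that of compound 1. Compound 3 is therefore expected to show a 2.7-fold higher number from compound 2 to compound 3 (0.43 log units; beyond the scatter) in this assay, landing at an estimated 0.8 nM with a range from 0.3 nM to 2.5 nM.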

Compound 3, half-maximal inhibitory concentration: 0.9 nM
Beside the measured number, compound 3's estimate is 1.1-fold (0.05 log units) below it, within the range that was stated.
By their numbers in this assay, from the lowest: compound 2; then compounds 1 and 3 (each within the scatter of the next).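

In this assay, replacing hydroxy(phenyl)methyl with 1-methoxy-1-methylethyl gives a 3.0-fold higher number from compound 2 to compound 3 (0.48 log units; beyond the scatter), so the lower number of compound 2 is lost when this group leaves. Among these compounds, exchanging one ether-containing group for another makes no readable difference, with a 1.1-fold higher number from compound 1 to compound 3 (0.05 log units; within the scatter); at this spot, isopropoxy and 1-methoxy-1-methylethyl cannot be told apart by this read-out, and compound 2 remains the only compound whose number stands clearly apart from the others. No supporting measurement is available to explain why the numbers fall this way.

The step from compound 2 to compound 3 removes a six-membered aromatic ring, a hydrogen-bond donor and a defined stereocentre together, while the group shrinks from 8 heavy atoms to 5, so the compounds shown cannot assign the step to any one of these differences. From the compounds shown here alone, a plain 2-phenylethyl group, which keeps the ring but carries no hydroxyl, or an amine at the same spot would begin to separate them, and how either would read in this assay remains open.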